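The source may hold more compounds than are shown below. What is called first, only, known or untested is meant among the compounds shown, and "the series" means these compounds.

Measured in a functional assay on CAKI-1 cells (Homo sapiens) for antiproliferative activity; a lower number here means a stronger inhibitor of growth, a higher number a weaker inhibitor of growth:

compound 1 `Oc1cc(-c2ccc3ccccc3c2)nc2ncccc12`: 5620 nM
compound 2 `Cc1ccnc2nc(-c3cccc4ccccc34)cc(O)c12`: 12 nM
compound 3 `Cc1cc(C)c2c(O)cc(-c3cccc4ccccc34)nc2n1`: 9550 nM

In this assay compound 2 gives the lowest number of the three. Its methyl analogue compound 3 is a step of an 800-fold higher number from compound 2 to compound 3 (2.90 log units; beyond the scatter); the change is methyl in place of hydrogen on an aromatic carbon. Compound 1 stands near compound 3, and the gap between these two lies within the usual scatter, so no order between them is claimed. The difference between the core of compound 1 and the core of compound 2 is not broken down here.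

The unmeasured compound 4 `Cc1ccc2c(O)cc(-c3ccc4ccccc4c3)nc2n1` is derived from compound 1 by methyl in place of hydrogen on an aromatic carbon. Among the compounds with values here, this is the same kind of change as the one from compound 2 to compound 3, not the same: in compound 3 the site is also described as meta to a methyl group, and that descriptor is absent for compound 4. Within the data shown here, only this single pair is available as a precedent, and it rests on a different core, so the expectation is loose.

Given that compound 1 already gives 5620 nM in this assay, and that the one precedent is the step of an 800-fold higher number from compound 2 to compound 3 (2.90 log units; beyond the scatter), a weakening is expected for compound 4, though a smaller one is estimated because compound 1 gives 5620 nM to begin with; the estimated step is a 5.3-fold higher number from compound 1 to compound 4 (0.73 log units; beyond the scatter). For compound 4 an estimate of 30000 nM is made, between 8000 nM and 100000 nM, with a real chance that only a limit is reported.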

Compound 4, concentration for 50% growth inhibition: 5370 nM
Beside the measured number, compound 4's estimate is 5.6-fold (0.75 log units) above it; the measured number lies below the stated range.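

In this assay, methyl in place of hydrogen on an aromatic carbon does not behave as a fixed, transferable step in this series, and the two cores give clearly different results: the same change on two cores in this assay, an 800-fold higher number (2.90 log units; beyond the scatter) from compound 2 to compound 3 and a 1.0-fold lower number (0.02 log units; within the scatter) from compound 1 to compound 4, 830-fold (2.92 log units) apart, beyond the scatter of two such steps

On the core of compound 1, the new step is a 1.0-fold lower number from compound 1 to compound 4 (0.02 log units; within the scatter), so this methyl gives no measurable separation between that pair, whereas the same kind of change on the other core gives a large loss of growth inhibition. Within the data shown here, this does not show what underlies the divergence: each core supplies only one pair, the two methyl sites are not described alike, and the data cannot separate the effect of the core from that of the site, nor show how the change would behave on a third core.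

The compounds shown leave open how an ethyl group, a methoxy group or an amine at the methyl-bearing carbon would read on either core. They also leave open which structural features of compound 2 are needed for its low number of 12 nM, and whether the hydroxyl group or the naphthyl attachment contributes to it.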